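The source may hold more compounds than are shown below. What is called first, only, known or untested is meant among the compounds shown, and "the series" means these compounds.

Compound 1, `CN1CCN(c2nc3cc(C(C)(C)C)ccc3o2)CC1`: < 4 in a functional assay on ileum (strain Hartley) for agonist activity at 5-hydroxytryptamine receptor 3A (Cavia porcellus); on this read-out higher numbers stand for higher potency (the scale is a negative logarithm) and lower numbers for lower potency
Compound 2, `CN1CCN(c2nc3cc([N+](=O)[O-])ccc3o2)CC1`: 6.1 in this assay

In this assay compound 1 gives < 4, which is a limit of the assay and not a number, as recorded at the limit of < 4 in this assay, at which 1 of the 2 values shown sits. Among the compounds with values here, compound 2 gives 6.1 in this assay, the only number available. Within the data shown here, the one measured step, a number at least 2.10 log units higher from compound 1 to compound 2 (beyond the scatter), came with nitro in place of tert-butyl on an aromatic carbon.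

Compound 3, `CN1CCN(c2nc3cc(F)ccc3o2)CC1`, differs from compound 2 by fluoro in place of nitro on an aromatic carbon. Among the measured compounds shown here, the step from compound 1 to compound 2 is the only measured comparison and bears on this change only loosely: it shows that the nitro partner outperforms tert-butyl, but fluoro resembles neither. Compound 3 is therefore expected to lose potency by a number 1.10 log units lower from compound 2 to compound 3 (beyond the scatter), a drop beyond the scatter, with the estimate for compound 3 at 5 and a range from 4 to 6.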

Compound 3, negative logarithm of the half-maximal effective concentration: 5.57
The estimate for compound 3 lay 0.57 log units below the measured number; the measured number falls inside the stated range.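

Fluoro in place of nitro brought a number 0.53 log units lower from compound 2 to compound 3 (beyond the scatter) in this assay, so a measurable response at this position does not require the nitro group, and a single fluorine, with no hydrogen-bond acceptors counted on the group, retains most of it. Fluoro in place of tert-butyl brought a number at least 1.57 log units higher from compound 1 to compound 3 (beyond the scatter), so the large gain over tert-butyl is not particular to nitro: among the three groups, tert-butyl is the one that stands apart. Compound 1 remains a limit of the assay and not a number: the limit of < 4 in this assay, at which 1 of the 3 values shown sits.

The compounds shown leave open how chloro, methoxy or an amine at this same position would read, and so whether the order seen here holds beyond these three groups. They also do not tell what separates tert-butyl from nitro and fluoro.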